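This account rests on a few compounds, and the source may have more. Where it says the series, first, only, none or still open, it means among the compounds named here.

Working notes on the series. Three compounds share the core of compound 1 `Cc1nc(S(C)(=O)=O)ccc1Oc1ncnc(OC2CCN(C(=O)OC(C)(C)C#N)CC2)c1F` and differ only in the group on the carbonyl carbon of the piperidine. In a functional assay on isolated protein for inhibition of Glucose-dependent insulinotropic receptor (Rattus norvegicus), read by HTRF and cAMP accumulation (on this read-out lower numbers stand for smaller maximal responses and higher numbers for larger maximal responses), compound 1 gives 97%. Compound 2 `Cc1nc(S(C)(=O)=O)ccc1Oc1ncnc(OC2CCN(C(=O)OC3(C(F)(F)F)CCC3)CC2)c1F` gives 82% in this assay, a change of a number 15 percentage points lower from compound 1 to compound 2 (beyond the scatter). Compound 3 `Cc1nc(S(C)(=O)=O)ccc1Oc1ncnc(OC2CCN(C(=O)SC3(C)CC3)CC2)c1F` gives 77% in this assay; the step is a number 20 percentage points lower from compound 1 to compound 3 (beyond the scatter), while the step of a number 5 percentage points lower from compound 2 to compound 3 (within the scatter) lies within the scatter. Compound 3 therefore sits at the low end of the three numbers, separated from compound 1 beyond the scatter but not from compound 2.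

Compound 4 `Cc1nc(S(C)(=O)=O)ccc1Oc1ncnc(OC2CCN(C(=O)C3(F)CCC3)CC2)c1F` is not yet measured. It differs from compound 3 by a group of 5 heavy atoms (4 carbon, 1 fluorine; one four-membered non-aromatic ring of carbon only) in place of a group of 5 heavy atoms (4 carbon, 1 sulfur; one three-membered non-aromatic ring of carbon only), on a carbonyl carbon. The nearest comparison is the step of a number 5 percentage points lower from compound 2 to compound 3 (within the scatter), a replacement of one ring-bearing group by another on the same carbonyl carbon that stayed within the scatter; the larger step of a number 20 percentage points lower from compound 1 to compound 3 (beyond the scatter) involved a group without a ring and bears less directly. A step of a number 2 percentage points lower from compound 3 to compound 4 (within the scatter) is expected, that is, no change beyond the scatter. Compound 4 is estimated at 75% in this assay, within the range 60% to 90%.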

Compound 4, largest response reached (reported as efficacy), in percent of the reference or control that the assay uses: 91%
For compound 4 the middle estimate is 16 percentage points below the measured one, and the stated range ends below it.
By their numbers in this assay, from the lowest: compounds 3, 2, 4 and 1 (each within the scatter of the next, the first and the last beyond it).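

Two groups with the same heavy-atom count on the carbonyl carbon are separated in this assay: the group with fluorine and a four-membered ring, in place of the group with sulfur and a three-membered ring, gives a number 14 percentage points higher from compound 3 to compound 4 (beyond the scatter). The steps of a number 9 percentage points higher from compound 2 to compound 4 (within the scatter) and a number 6 percentage points lower from compound 1 to compound 4 (within the scatter) both stay within the scatter, although the step of a number 15 percentage points lower from compound 1 to compound 2 (beyond the scatter) does not. A ring-bearing group on this carbonyl carbon can therefore give a number within the scatter of compound 1, which neither of the two earlier ring-bearing compounds did.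

No evidence is available that accounts for the step to the fluorine-bearing group. Still open, on these data alone, is how a cyclobutyl group without fluorine, or one carrying an amine, would compare on this carbonyl carbon.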